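Chlorophenyl for trifluoromethylphenyl on a shared quinone core

This account rests on a few compounds, and the source may have more. Where it says the series, first, only, none or still open, it means among the compounds named here.

The series rests on one core, seen first in compound 1 `O=C1C=C(NC2CCCC2)C(=O)c2c1nc1n2[C@H]2OC[C@@H](O)[C@H]2OC1`, where a cyclopentyl group sits on the amine nitrogen. In a functional assay on MCF7 cells (Homo sapiens) for inhibition, read by sulforhodamine B assay (on this read-out higher numbers stand for weaker inhibition and lower numbers for stronger inhibition), compound 1 gives > 16000 nM, which is a limit of the assay and not a number. Compound 3 `O=C1C=C(Nc2ccc(C(F)(F)F)cc2)C(=O)c2c1nc1n2[C@H]2OC[C@@H](O)[C@H]2OC1` carries a 4-(trifluoromethyl)phenyl group on the same nitrogen; in this assay compound 3 gives > 4000 nM, again a limit. The step that the two limits leave unreadable from compound 1 to compound 3 therefore cannot be read, since both ends sit at limits the limit of > 16000 nM in this assay, at which 1 of the 3 values shown sits (the limit of > 4000 nM in this assay, at which 2 of the 3 values shown sit). Compound 2 `O=C1C(Nc2ccc(C(F)(F)F)cc2)=CC(=O)c2c1nc1n2[C@H]2OC[C@@H](O)[C@H]2OC1` places the 4-(trifluoromethyl)phenyl amine on the other carbon of the quinone ring. In this assay compound 2 gives > 4000 nM, a limit of the assay; compound 2 thus stands among the two of three values that sit at this limit.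

Compound 4 `O=C1C(Nc2cccc(Cl)c2)=CC(=O)c2c1nc1n2[C@H]2OC[C@@H](O)[C@H]2OC1` differs from compound 2 by 3-chlorophenyl in place of 4-(trifluoromethyl)phenyl on an amine nitrogen. Within the data shown here, no measured step bears on this change; the single step recorded in the set is unreadable, and every value shown is a limit. For compound 4 the step that the limit leaves unreadable from compound 2 to compound 4 is expected to be small or absent beyond the scatter, with the outcome most likely another limit. Compound 4 is accordingly estimated at 8000 nM, within 2000 nM to 40000 nM.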

Compound 4, half-maximal inhibitory concentration: 2970 nM
Compound 4: the middle estimate sits 2.7-fold (0.43 log units) above what was measured; the measured number falls inside the stated range.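

Compound 4 is the only compound shown that gives a number rather than a limit in this assay, so it gives this amine nitrogen position on the shared core its first readable value, with 3-chlorophenyl as the group there. Putting 3-chlorophenyl in place of 4-(trifluoromethyl)phenyl gives an at least 1.3-fold lower number from compound 2 to compound 4 (0.12 log units; that floor lies within the scatter), and since compound 2 stands at a limit, this is only a floor: the true step may be larger, but what is printed does not go beyond the usual scatter. The values shown offer no explanation for this step, and nothing here separates the effect of the chlorine from that of the trifluoromethyl group being removed.

Still open, as far as these compounds go, is whether 3-chlorophenyl would also give a number with the amine placed as in compound 3, the placement that carries the same nitrogen in compound 1. Also open, from the compounds shown here alone, is how a plain phenyl, a 4-chlorophenyl or a 3-methoxyphenyl group would read on this amine nitrogen, which would show whether the value of compound 4 belongs to the chlorine, to where it sits on the ring, or to neither.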